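Working notes: ethylamino in place of dimethylamino

The source may hold more compounds than are shown below. What is called first, only, known or untested is meant among the compounds shown, and "the series" means these compounds.

Among the compounds with values here, compound 1 `Cc1nnc(CN(C)C)n1-c1ccc(Cl)cc1C(=O)c1ccccc1` is the only compound in this set with a numerical result in a functional assay on the whole organism (strain CF-1) for inhibition, with Mus musculus as the target; on this read-out lower numbers stand for an effect already at smaller amounts and higher numbers for an effect only at larger amounts of compound; in that assay compound 1 gives 45 mg/kg. Compound 2 `CN(C)Cc1nn(CO)c(=O)n1-c1ccc(Cl)cc1C(=O)c1ccccc1Cl` is measured in this assay as well, but for compound 2 the result > 100 mg/kg is a limit of the assay and not a number. Within the data shown here, the one remaining observation is therefore (the limit of > 100 mg/kg in this assay, at which 1 of the 2 values shown sits), which gives no step to compare.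

Compound 3 `CCNCc1nnc(C)n1-c1ccc(Cl)cc1C(=O)c1ccccc1` has not yet been measured in this assay. It differs from compound 1 by ethylamino in place of dimethylamino on a saturated chain carbon bound to an aromatic carbon. Among the measured compounds shown here, no step between measured compounds touches this position, so no direction can be read from the data. The change is expected to stay close to or within the usual scatter, with the step from compound 1 to compound 3 estimated as a 1.1-fold higher number from compound 1 to compound 3 (0.05 log units; within the scatter) in this assay. On that basis compound 3 is expected to give about 50 mg/kg in this assay, estimated within a range from 20 mg/kg to 150 mg/kg.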

Compound 3, dose for half-maximal effect: 45 mg/kg
Beside the measured number, compound 3's estimate is 1.1-fold (0.05 log units) above it; the range from low to high includes it.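

In this assay, within the data shown here, ethylamino in place of dimethylamino on a saturated chain carbon bound to an aromatic carbon gives no change at the digits printed from compound 1 to compound 3 (within the scatter) and provides the first readable step at this position. The two groups have the same 3 heavy atoms, yet the change goes from 0 hydrogen-bond donors to 1 hydrogen-bond donor, and in this single pair that difference comes with a step within the scatter. No measurement shown bears on a cause for this result.

This single pair leaves open whether the read-out also stays within the scatter with a primary amine, a longer chain such as propylamino, or a ring amine such as morpholine at the same place, and no trend can be drawn from one replacement. For compound 2 the result in this assay is > 100 mg/kg and is a limit of the assay, so steps to that compound cannot be read.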